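The source may report more compounds than this note shows. Statements on the series, on what has been measured and on what is new or still open speak of the compounds shown alone.

Measured compounds and their values:
compound 1, `OCc1ccc(-c2nn(Cc3ccccn3)c3ccccc23)o1`; in a functional assay (aorta) with Oryctolagus cuniculus as the target (a lower number here means a stronger inhibitor, a higher number a weaker inhibitor), compound 1 gives 16000 nM
compound 2, `NS(=O)(=O)c1ccc(-c2nn(Cc3ccccc3F)c3ncccc23)o1`; in this assay compound 2 gives 8000 nM
compound 3, `CCCCCc1cnc(-c2nn(Cc3ccccc3F)c3ncccc23)nc1N`; in this assay compound 3 gives 200000 nM

Compound 3 gives the highest number of the three. Compound 1 stands nearest to it and compound 2 furthest, and both gaps lie beyond the scatter, so compound 3 is the weakest inhibitor of the three in this assay. Going by the values given here, no two measured compounds differ in one place only, so no measured step is available as a guide.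

Compound 4, `Nc1nc(-c2nn(Cc3ccccc3F)c3ncccc23)ncc1CC(F)(F)F`, is not yet measured in this assay. Against compound 3 the change is trifluoromethyl in place of butyl on a saturated chain carbon bound to an aromatic carbon. Among the compounds with values here, none of the measured compounds carries either group, so nothing here shows what this exchange does in this assay. The step is therefore expected to be small, with no direction beyond the scatter. The expected step is no change at the digits printed from compound 3 to compound 4 (within the scatter). For compound 4 the estimate in this assay is 200000 nM, with a range from 60000 nM to 600000 nM.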

Compound 4, half-maximal inhibitory concentration: 508000 nM
Compound 4: middle estimate off by 2.5-fold (0.40 log units), on the low side; the measured number falls inside the stated range.
By their numbers in this assay, from the lowest: compounds 2 and 1 (each within the scatter of the next); then compound 3; then compound 4.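

In this assay, going by these compounds alone, this is the first pair that differs in one place, and the exchange of butyl for trifluoromethyl on a saturated chain carbon bound to an aromatic carbon gives a 2.5-fold higher number from compound 3 to compound 4 (0.40 log units; beyond the scatter). The position therefore responds to this change, and the step runs towards weaker inhibition, even though both groups count the same number of heavy atoms and the pair adds no ring, donor, acceptor or charge. No measured property accounts for the step.

One pair cannot separate the loss of the butyl carbons from the entry of fluorine, and a plain ethyl or propyl chain in the same place would bear on that. Going by these compounds, whether an amine or a carboxylic acid at the chain end would lower the number also remains open.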